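The source may hold more compounds than are shown below. What is called first, only, known or untested is meant among the compounds shown, and "the series" means these compounds.

Three compounds have been measured in an ADME assay on the whole organism for cytotoxicity, with Artemia salina as the target, with a stated time of 24 h; a lower number here means that less compound is needed, a higher number that more compound is needed for the effect:
compound 1 `Cc1ccc(S(=O)(=O)NC(=O)Nc2ccccc2C(=O)/C=C/c2ccccc2)cc1` gives 25 ug/mL;
compound 2 `Cc1ccc(/C=C/C(=O)c2ccccc2NC(=O)NS(=O)(=O)c2ccc(C)cc2)cc1` gives 15.3 ug/mL;
compound 3 `CCOc1cc(/C=C/C(=O)c2ccccc2NC(=O)NS(=O)(=O)c2ccc(C)cc2)ccc1O` gives 19.2 ug/mL.

Compound 2 has the lowest of the three numbers, but both steps that involve it lie within the scatter: a 1.6-fold lower number from compound 1 to compound 2 (0.21 log units; within the scatter) and a 1.3-fold higher number from compound 2 to compound 3 (0.10 log units; within the scatter). Compound 4 `Cc1ccc(S(=O)(=O)NC(=O)Nc2ccccc2C(=O)/C=C/c2ccccc2[N+](=O)[O-])cc1` differs from compound 2 in one place: 2-nitrophenyl in place of 4-methylphenyl on a double-bonded chain carbon bound to a double-bonded chain carbon. The measured steps that bear on this change are those at the same place, a 1.3-fold lower number from compound 1 to compound 3 (0.11 log units; within the scatter) and a 1.3-fold higher number from compound 2 to compound 3 (0.10 log units; within the scatter), both within the scatter, as is a 1.6-fold lower number from compound 1 to compound 2 (0.21 log units; within the scatter). For the measured compounds named here, none of the measured compounds carries a nitro group. On this basis no step beyond the scatter is expected in this assay. For compound 4 the expected value is 20 ug/mL, with a range from 9 ug/mL to 45 ug/mL, which means an expected step of a 1.3-fold higher number from compound 2 to compound 4 (0.12 log units; within the scatter).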

Compound 4, concentration for half-maximal effect: 40.1 ug/mL
Estimate against measurement, compound 4: 2.0-fold (0.30 log units) below, and the stated range covers the measured number.
By their numbers in this assay, from the lowest: compounds 2, 3, 1 and 4 (each within the scatter of the next, the first and the last beyond it).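

In this assay, for the compounds shown here, the 2-nitrophenyl group gives the first steps beyond the scatter at this place, with a 2.6-fold higher number from compound 2 to compound 4 (0.42 log units; beyond the scatter) and with a 2.1-fold higher number from compound 3 to compound 4 (0.32 log units; beyond the scatter) as well. The nitro group alone, however, stays within the scatter, with a 1.6-fold higher number from compound 1 to compound 4 (0.21 log units; within the scatter) on the same core, so compound 4 stands apart from compounds 2 and 3 but not from compound 1. No measurement offers an explanation for these steps. As far as these compounds go, what an amine or a carboxylic acid in place of the nitro group would give in this assay remains open.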